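A few compounds are considered here, and "the series" means these few. Any claim that something is new, unique, unknown or untested is made for them only; others in the source may bear on it.

In a functional assay on HepG2 cells (Homo sapiens) for antiproliferative activity, read by MTT assay, with a stated time of 24 h (on this read-out lower numbers stand for stronger inhibition and higher numbers for weaker inhibition), compound 2 `COc1cc(OC)c(-c2coc3cc(OCc4ccc(Br)cc4)ccc3c2=O)cc1OC` gives 1050 nM and compound 3 `COc1cc(OC)c(-c2coc3cc(OCc4ccc([N+](=O)[O-])cc4)ccc3c2=O)cc1OC` gives 2500 nM, the higher of these two numbers. Compound 1 `COc1cc(OC)c(-c2coc3cc(OCC(=O)c4cccc(C(F)(F)F)c4)ccc3c2=O)cc1OC` is recorded at > 10000 nM, which is a limit of the assay and not a number. Compound 4 `COc1cc(OC)c(-c2coc3cc(OCc4ccccc4C#N)ccc3c2=O)cc1OC` keeps the shared core of compound 3 and changes one group: 2-cyanophenyl in place of 4-nitrophenyl on a saturated chain carbon bound to an oxygen on an aromatic ring. In words, 2-cyanophenyl stands in place of 4-nitrophenyl on a saturated chain carbon bound to an oxygen on an aromatic ring.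

The nearest measured change is the swap of nitro for bromo on the aromatic ring, a modest 2.4-fold higher number from compound 2 to compound 3 (0.38 log units; beyond the scatter). The larger steps, an at least 9.5-fold lower number from compound 1 to compound 2 (0.97 log units; beyond the scatter) and an at least 4.0-fold lower number from compound 1 to compound 3 (0.60 log units; beyond the scatter), remove the carbonyl-bearing group of compound 1, a different kind of change, so they bear on this one less directly. Going by the modest step alone, only a small shift is expected, with no clear direction and nothing beyond the scatter: the expected step is a 1.3-fold lower number from compound 3 to compound 4 (0.10 log units; within the scatter). Compound 4 is estimated at 2000 nM, with an expected range from 700 nM to 6000 nM.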

Compound 4, half-maximal inhibitory concentration: > 10000 nM
Compound 4 was reported as a limit; the forecaster's own chance of this, stated with the estimate: 10%; at least 5.0-fold (0.69 log units) between middle value and limit.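

Replacing 4-nitrophenyl with 2-cyanophenyl on a saturated chain carbon bound to an oxygen on an aromatic ring gives an at least 4.0-fold higher number from compound 3 to compound 4 (0.60 log units; beyond the scatter), and the same group in place of 4-bromophenyl gives an at least 9.5-fold higher number from compound 2 to compound 4 (0.97 log units; beyond the scatter). Until now only compound 1, with its carbonyl-bearing group, had reached the limit, so a carbonyl on the chain is not needed for a compound to read this weakly in this assay. Compound 4 stands at a limit of the assay and not at a number, and it shares that limit with compound 1, so the step between these two cannot be read: the limit of > 10000 nM in this assay, at which 2 of the 4 values shown sit.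

Going by these compounds, it stays open whether the change follows the nitrile itself or its place on the ring. A 4-cyanophenyl or a 2-bromophenyl group on this carbon would separate the two, and a 4-aminophenyl group would show how an amine fares here.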